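Another Aryl Swap on the Amide of the Shared Core

This account rests on a few compounds, and the source may have more. Where it says the series, first, only, none or still open, it means among the compounds named here.

Among the two compounds measured so far in a functional assay on HCT-116 cells (Homo sapiens) for cytotoxicity, read by MTT assay, with a stated time of 72 h (on this read-out higher numbers stand for weaker inhibition and lower numbers for stronger inhibition), compound 2 `CN1[C@@H]2c3[nH]c4ccccc4c3C[C@H]1[C@H](C#N)N1[C@@H](CNC(=O)c3cc4ccccc4o3)c3[nH]c4ccccc4c3C[C@@H]21` gives 330 nM, and compound 1 `CN1[C@@H]2c3[nH]c4ccccc4c3C[C@H]1[C@H](C#N)N1[C@@H](CNC(=O)c3ccc(Cl)cc3)c3[nH]c4ccccc4c3C[C@@H]21` gives 630 nM in this assay; the step of a 1.9-fold lower number from compound 1 to compound 2 (0.28 log units; within the scatter) separates them only within the scatter, so neither can be set apart from the other. Compound 3 `COc1ccc(/C=C/C(=O)NC[C@H]2c3[nH]c4ccccc4c3C[C@H]3[C@H]4c5[nH]c6ccccc6c5C[C@@H]([C@H](C#N)N23)N4C)cc1` differs from compound 2 by 2-(4-methoxyphenyl)ethenyl in place of 1-benzofuran-2-yl on a carbonyl carbon. For the measured compounds named here, the only measured step that bears on this position is the exchange on the same carbonyl carbon from compound 1 to compound 2, and it stayed within the scatter. Going by the values given here, nothing among the measured compounds speaks for a change beyond the scatter when the group on that carbonyl is exchanged once more, so the expected step of a 1.2-fold higher number from compound 2 to compound 3 (0.08 log units; within the scatter) is small. Compound 3 is therefore estimated at 400 nM, with a range from 130 nM to 1300 nM.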

Compound 3, half-maximal inhibitory concentration: 5060 nM
Beside the measured number, compound 3's estimate is 13-fold (1.10 log units) below it; measured number above the stated range.
By their numbers in this assay, from the lowest: compounds 2 and 1 (each within the scatter of the next); then compound 3.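

In this assay, the position on the carbonyl carbon proves able to respond to an exchange, which the earlier pair did not show: the step is a 15-fold higher number from compound 2 to compound 3 (1.19 log units; beyond the scatter) and, against the other earlier compound, an 8.0-fold higher number from compound 1 to compound 3 (0.90 log units; beyond the scatter). The two compounds with an aromatic ring directly on the carbonyl carbon, compound 1 and compound 2, stay within the scatter of each other, while compound 3, with 2-(4-methoxyphenyl)ethenyl there, stands apart from both as the weakest of the three. No measurement on hand explains this loss of activity.

As far as these compounds go, what remains open is whether the double bond outside the aromatic rings or the methoxy group goes with the higher number, as the two enter together. A 4-methoxyphenyl group directly on the carbonyl carbon, or a plain 2-phenylethenyl group, would separate them.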